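Stretching the hydroxycarbamoyl chain from compound 3 to compound 4

The compounds below may be only part of what the source reports. "The series", "measured", "known", "first", "only" and "open" are said of these compounds alone.

In a functional assay on HCT-116 cells (Homo sapiens) for inhibition, read by MTT assay, with a stated time of 72 h (on this read-out lower numbers stand for stronger inhibition and higher numbers for weaker inhibition), compound 1 `CNC(=O)CCCCCCCn1nc(-c2cnc3[nH]ccc3c2)c2c(N)ncnc21` gives 6760 nM, but its structure differs in more than the chain, so it says little here. Compound 2 `Nc1nc2cc(-c3nn(CCCCCCCCCC(=O)NO)c4ncnc(N)c34)ccc2o1`, which carries 7-(hydroxycarbamoyl)heptyl on the chain, gives 23100 nM. Compound 3 `Nc1nc2cc(-c3nn(CCC(=O)NO)c4ncnc(N)c34)ccc2o1` gives > 100000 nM, which is a limit of the assay and not a number.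

Compound 4 `Nc1nc2cc(-c3nn(CCCCCC(=O)NO)c4ncnc(N)c34)ccc2o1` differs from compound 3 by 3-(hydroxycarbamoyl)propyl in place of hydroxycarbamoyl on a saturated chain carbon, two bonds along the chain from an aromatic nitrogen: 3-(hydroxycarbamoyl)propyl in place of hydroxycarbamoyl, on a saturated chain carbon, two bonds along the chain from an aromatic nitrogen. Within the data shown here, the group that enters is still shorter than the one in compound 2.

Among the measured compounds shown here, the one measured step that bears on this is an at least 4.3-fold higher number from compound 2 to compound 3 (0.63 log units; beyond the scatter), which swaps the same position and rests on (the limit of > 100000 nM in this assay, at which 1 of the 3 values shown sits). Running that step partly backwards suggests some recovery, though compound 4 may not reach compound 2. The expected change is an at least 2.5-fold lower number from compound 3 to compound 4 (0.39 log units; beyond the scatter), towards lower numbers. For compound 4 the estimated value is 40000 nM, with an expected range of 12000 nM to 100000 nM.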

Compound 4, half-maximal inhibitory concentration: 21500 nM
For compound 4 the middle estimate is 1.9-fold (0.27 log units) above the measured one; the range from low to high includes it.
By their numbers in this assay, from the lowest: compound 1; then compounds 4 and 2 (each within the scatter of the next). At a limit, above all of these: compound 3.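

In this assay the change gives an at least 4.6-fold lower number from compound 3 to compound 4 (0.66 log units; beyond the scatter) and so turns a limit into a readable value: the short chain of compound 3 is not the best this position can offer. The size of that step can only be given as a minimum, and it rests on a limit: (the limit of > 100000 nM in this assay, at which 1 of the 4 values shown sits). The other new step, a 1.1-fold lower number from compound 2 to compound 4 (0.03 log units; within the scatter), lies within the scatter, so the much longer chain of compound 2 shows no measurable difference from the chain of compound 4 in this assay.

As far as these compounds go, it remains open how a chain of intermediate length between those of compound 4 and compound 2, or one longer than that of compound 2, would read. From the compounds shown here alone, it is also open what a carboxylic acid in place of the hydroxycarbamoyl group on the chain of compound 4 would give.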